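The compounds below may be only part of what the source reports. "The series", "measured", "known", "first", "only" and "open" are said of these compounds alone.

Measured so far:
compound 1, `CCC(=O)c1ccc2oc(CS(=O)(=O)c3nnc(CNc4ccccc4)n3CC)nc2c1`: 1670 nM
compound 2, `CC/C(=N/OC)c1ccc2oc(CSc3nnc(CNc4ccccc4)n3CC)nc2c1`: > 1000 nM
compound 3, `CCOC(=O)c1ccc(NC(=O)CSc2nnc(CSCc3ccccc3)n2CC)cc1`: 7600 nM

In an assay on isolated protein for inhibition of long-chain fatty acid transport protein 1 (Homo sapiens) (a lower number here means a stronger inhibitor, a higher number a weaker inhibitor), compound 1 gives 1670 nM and compound 3 gives 7600 nM. For compound 2 the assay reports only a limit, > 1000 nM, and not a number. This is the situation described by the limit of > 1000 nM in this assay, at which 1 of the 3 values shown sits: where compound 2 truly stands is open, beyond the statement that it is not a strong inhibitor in this assay.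

Compound 4, `CCn1c(CNc2ccccc2)nnc1SCc1nc2cc(OC(F)(F)F)ccc2o1`, keeps the thioether-linked pair of ring systems of compound 2 and differs from it in one place: a group of 5 heavy atoms (1 carbon, 1 oxygen, 3 fluorine; no ring) in place of a group of 6 heavy atoms (4 carbon, 1 nitrogen, 1 oxygen; no ring), on an aromatic carbon. Among the measured compounds shown here, no measured pair in the set shows what a change of this kind does in this assay, so no size or direction can be read off for the step from compound 2 to compound 4; the step is expected to lie within the scatter, or near it, rather than beyond it. Compound 4 is accordingly expected to give about 3000 nM in this assay, within 800 nM to 12000 nM, which means a step that the limit leaves unreadable from compound 2 to compound 4 from compound 2 to compound 4, with a fair chance that only a limit is again reported.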

Compound 4, half-maximal inhibitory concentration: 100 nM
Beside the measured number, compound 4's estimate is 30-fold (1.48 log units) above it; measured number below the stated range.
By their numbers in this assay, from the lowest: compound 4; then compound 1; then compound 3.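

On an aromatic carbon of the six-membered aromatic ring of carbon only, part of a fused system of two rings, the choice of group clearly counts in this assay: trifluoromethoxy in place of the group of 6 heavy atoms gives an at least 10-fold lower number from compound 2 to compound 4 (1.00 log units; beyond the scatter). Compound 2 carries only a limit, > 1000 nM. The printed size of this step is therefore a lower bound, because the true value of compound 2 remains open: the limit of > 1000 nM in this assay, at which 1 of the 4 values shown sits.

Going by these compounds, what a methoxy group, a chlorine atom or a carboxylic acid would give on the same aromatic carbon remains open, so the step cannot yet be tied to trifluoromethoxy in particular. Also open, on these data alone, is whether trifluoromethoxy gives a step of this kind when a sulfone takes the place of the thioether.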